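A few compounds are considered here, and "the series" means these few. Any claim that something is new, unique, unknown or untested is made for them only; others in the source may bear on it.

Compounds measured so far:
compound 1, `C[C@@H]1CCCN1c1c(C#N)c2c(N)nc(Nc3cn[nH]c3)nc2n1C`, 6 nM
compound 2, `Cn1c(NCc2ccccc2F)c(C#N)c2c(N)ncnc21`, 6060 nM
compound 3, `Cc1c(Nc2nc(N)c3c(C#N)c(N4CCC[C@H]4C)n(C)c3n2)cnn1CC(C)(C)O`, 43 nM

All three were tested in an assay on isolated protein for inhibition of Leucine-rich repeat serine/threonine-protein kinase 2 (Homo sapiens), read by TR-FRET and LanthaScreen, with stated times of 50 min and 30 min, in the presence of a further agent that is not named here; on this read-out lower numbers stand for stronger inhibition and higher numbers for weaker inhibition. Compound 1 shows the lowest number of the three. Compound 3 comes nearest to it, with a number that is higher by a margin beyond the scatter, and compound 2 is furthest, with a far higher number. For the measured compounds named here, no single-point step between measured compounds is available, so nothing is known directly about how a change on the 1H-pyrazol-4-yl group alone shifts the result.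

Compound 4, `C[C@@H]1CCCN1c1c(C#N)c2c(N)nc(Nc3cnn(C)c3)nc2n1C`, is not yet measured. It differs from compound 1 in one place: methyl in place of hydrogen on an aromatic nitrogen. Going by the values given here, with no measured step of this kind to lean on, the account expects a step that, if present at all, stays small, and weakening rather than strengthening is taken as the more likely direction, given that compound 3 with its substituted pyrazole sits at 43 nM. The step from compound 1 to compound 4 is expected to be a 1.8-fold higher number from compound 1 to compound 4 (0.26 log units; within the scatter). Compound 4 is estimated at 11 nM, within a range from 3 nM to 40 nM.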

Compound 4, half-maximal inhibitory concentration: 6 nM
For compound 4 the middle estimate is 1.8-fold (0.26 log units) above the measured one; the range from low to high includes it.
By their numbers in this assay, from the lowest: compounds 1 and 4 (each within the scatter of the next); then compound 3; then compound 2.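

In this assay methyl in place of hydrogen on an aromatic nitrogen of the 1H-pyrazol-4-yl group gives no change at the digits printed from compound 1 to compound 4 (within the scatter) and so provides the first single-point step among these compounds. It shows that the hydrogen on this nitrogen is not needed to keep the number seen for compound 1, and that this position accepts one added carbon with no shift beyond the scatter. Nothing shown here explains why the step is this small.

The compounds shown leave open whether this nitrogen accepts more than a methyl, such as an ethyl, a longer chain, or a chain ending in an amine or a carboxylic acid. As far as these compounds go, it also remains open whether the same step would hold with a different group elsewhere on the shared core.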